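A few compounds are considered here, and "the series" means these few. Any claim that something is new, unique, unknown or untested is made for them only; others in the source may bear on it.

Measured compounds:
- compound 1, `O=c1[nH]c(=O)n([C@H]2C[C@H](O)[C@@H](CO)O2)cc1C#CC#Cc1ccccc1`: 100000 nM
- compound 2, `Nc1ccc(C#CC#Cc2cn([C@H]3C[C@H](O)[C@@H](CO)O3)c(=O)[nH]c2=O)cc1`: > 100000 nM
- compound 3, `O=c1[nH]c(=O)n([C@H]2C[C@H](O)[C@@H](CO)O2)cc1C#CC#Cc1ccc([N+](=O)[O-])cc1`: 89000 nM

In an ADME assay on HEL cells (Homo sapiens), read by cell counting, with a stated time of 3 days (on this read-out higher numbers stand for lower toxicity in this test and lower numbers for higher toxicity in this test), compound 1 gives 100000 nM. For compound 2 the result in this assay is a limit, > 100000 nM, not a number (the limit of > 100000 nM in this assay, at which 1 of the 3 values shown sits). Compound 3 gives 89000 nM in this assay, the lower of the two numbers shown; its nearest neighbour is compound 1, and the step of a 1.1-fold lower number from compound 1 to compound 3 (0.05 log units; within the scatter) sits within the scatter. Going by these compounds, the step of an at least 1.1-fold lower number from compound 2 to compound 3 (0.05 log units; that floor lies within the scatter) rests on a limit, so its size stays open, as does a number no lower from compound 1 to compound 2 (the limit leaves the size open).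

Compound 4, `CC(O)CC#CC#Cc1cn([C@H]2C[C@H](O)[C@@H](CO)O2)c(=O)[nH]c1=O`, is not yet measured. It differs from compound 3 by 2-hydroxypropyl in place of 4-nitrophenyl on a triple-bonded carbon. Among the compounds with values here, no measured step covers a change of this kind; the measured steps only vary a substituent on the aromatic ring, and none moved the number beyond the scatter. All three measured results cluster at the upper end of this assay. On that basis, the step of a 1.1-fold higher number from compound 3 to compound 4 (0.05 log units; within the scatter) is expected to stay within the scatter, and compound 4 is estimated at 100000 nM, with a range from 50000 nM to 200000 nM, with a fair chance that this assay again reports only a limit.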

Compound 4, half-maximal cytotoxic concentration: 9500 nM
For compound 4 the middle estimate is 11-fold (1.02 log units) above the measured one; the whole stated range lies above it.
By their numbers in this assay, from the lowest: compound 4; then compounds 3 and 1 (each within the scatter of the next).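

In this assay, 2-hydroxypropyl in place of the phenyl-type groups on the triple-bonded carbon is the only change shown that moves the number beyond the scatter, towards higher toxicity in this test (a 9.4-fold lower number from compound 3 to compound 4 (0.97 log units; beyond the scatter) and an 11-fold lower number from compound 1 to compound 4 (1.02 log units; beyond the scatter) and an at least 10-fold lower number from compound 2 to compound 4 (1.02 log units; beyond the scatter)). This position therefore tolerates swaps on the aromatic ring without a readable change, yet responds when the ring itself leaves. The result for compound 2 is a limit, not a number, so its step gives only a floor: the limit of > 100000 nM in this assay, at which 1 of the 4 values shown sits.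

The compounds shown do not separate the loss of the ring from the arrival of the hydroxyl, since no plain propyl or hydroxyl-bearing phenyl stands among them. Going by these compounds, how a longer chain, an amine or a carboxylic acid on this carbon would read also remains open.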